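The source may report more compounds than this note shows. Statements on the series, on what has been measured and on what is new or still open speak of the compounds shown alone.

Measured compounds:
- compound 1 `Cc1cc(COc2ccc(F)cc2F)nc(-c2ccccn2)n1`, 398 nM
- compound 2 `CC1(C)CN(c2cc(COc3ccc(F)c(F)c3F)nc(-c3ccccn3)n2)C1`, 25.1 nM
- compound 3 `Fc1ccc(OCc2cc(N3CC4(CCO4)C3)nc(-c3ccccn3)n2)c(F)c1F`, 501 nM

In a functional assay on cells for antagonist activity at Free fatty acid receptor 1 (Homo sapiens), read by TR-FRET and inositol phosphate accumulation, with a stated time of 2 h (on this read-out higher numbers stand for weaker inhibition and lower numbers for stronger inhibition), compound 3 holds the highest number of the three. Compound 1 sits within the scatter of it, so no order between those two is claimed. Going by the values given here, compound 2 stands apart: the step of a 20-fold higher number from compound 2 to compound 3 (1.30 log units; beyond the scatter) is large and well beyond the scatter, and it is the only measured step in this set.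

Compound 4 `CC1(C#N)CN(c2cc(COc3ccc(F)c(F)c3F)nc(-c3ccccn3)n2)C1` is the next step from compound 3: a group of 7 heavy atoms (5 carbon, 2 nitrogen; one four-membered non-aromatic ring with 1 hetero atom) in place of a group of 7 heavy atoms (5 carbon, 1 nitrogen, 1 oxygen; 2 four-membered non-aromatic rings with 1 hetero atom each), on an aromatic carbon. The group entering keeps one four-membered ring with a methyl at the same carbon as in compound 2 and carries a nitrile in place of the second methyl. Among the compounds with values here, the only step that bears on this change is the one from compound 2 to compound 3, which moved the number a long way up. Reversing part of that change is expected to move it back down, though the nitrile is untested here, so the full return to compound 2 is not assumed. For compound 4 the expected step is an 8.0-fold lower number from compound 3 to compound 4 (0.90 log units; beyond the scatter), a clear move downward beyond the scatter. Compound 4 is therefore estimated at 63 nM, with a range of 20 nM to 200 nM.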

Compound 4, half-maximal inhibitory concentration: 158 nM
Compound 4: middle estimate off by 2.5-fold (0.40 log units), on the low side, within the range that was stated.
By their numbers in this assay, from the lowest: compound 2; then compound 4; then compounds 1 and 3 (each within the scatter of the next).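

In this assay the 3-cyano-3-methylazetidin-1-yl group gives a 3.2-fold lower number from compound 3 to compound 4 (0.50 log units; beyond the scatter) and places compound 4 between the two other compounds that carry a group at this position, as both this step and the next lie beyond the scatter. Cyano in place of methyl on the saturated ring carbon gives a 6.3-fold higher number from compound 2 to compound 4 (0.80 log units; beyond the scatter) and shows that a change at this one ring carbon, with the four-membered ring kept, is enough to move the number. No data shown here account for either step.

Going by these compounds, how a hydroxyl group, a fluorine atom or an ethyl group on that saturated ring carbon would compare with methyl and cyano remains open. Also open, on these data alone, is how an open-chain dimethylamino group would compare with the four-membered ring on the aromatic carbon.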